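The source may hold more compounds than are shown below. What is called first, only, known or untested is meant among the compounds shown, and "the series" means these compounds.

Measured so far:
compound 1, `CN(Cc1ccc(OCCCN)cc1)c1nc2ccc(Oc3ccc(C#N)cc3)cc2s1`: 65000 nM
compound 2, `NCCCOc1ccc(CNc2nc3ccc(Oc4ccc(O)cc4)cc3s2)cc1`: 205000 nM
compound 3, `CN(Cc1ccc(OCCCNC(=N)N)cc1)c1nc2ccc(Oc3ccc(O)cc3)cc2s1`: 432000 nM

All three values come from an assay on SH-SY5Y cells for inhibition of Voltage-dependent N-type calcium channel subunit alpha-1B (Homo sapiens), read by FLIPR and calcium flux, with stated times of 600 s and 300 s, in the presence of a further agent that is not named here; on this read-out lower numbers stand for stronger inhibition and higher numbers for weaker inhibition. Compound 1 stands lowest of the three numbers; compound 2 is the nearest to it and compound 3 the furthest, and both gaps lie beyond the scatter, so compound 1 is the strongest inhibitor of the three measured. Among the compounds with values here, each of the measured compounds differs from the others in more than one place, so no single step between measured compounds can be read off for any one change.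

Compound 4, `CN(Cc1ccc(OCCCN)cc1)c1nc2ccc(Oc3cccc(C(F)(F)F)c3)cc2s1`, is not yet measured. It departs from compound 1 by one change: 3-(trifluoromethyl)phenyl in place of 4-cyanophenyl on an oxygen on an aromatic ring. The shared core and the chain bearing the amine are kept.

Within the data shown here, no measured pair isolates a change at this position, so the expectation rests on compound 1 alone. The expected step is a 1.3-fold lower number from compound 1 to compound 4 (0.11 log units; within the scatter), a shift that is not expected to exceed the scatter in either direction. Compound 4 is therefore expected to give 50000 nM in this assay, with a range from 15000 nM to 160000 nM, anchored on compound 1 at 65000 nM.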

Compound 4, half-maximal inhibitory concentration: 77000 nM
Estimate against measurement, compound 4: 1.5-fold (0.19 log units) below; the measured number falls inside the stated range.
By their numbers in this assay, from the lowest: compounds 1 and 4 (each within the scatter of the next); then compound 2; then compound 3.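

In this assay, within the data shown here, the exchange of 4-cyanophenyl for 3-(trifluoromethyl)phenyl on an oxygen on an aromatic ring gives a 1.2-fold higher number from compound 1 to compound 4 (0.07 log units; within the scatter) and is the first single-place step, so this position takes the change without a shift beyond the scatter. The leaving group counts a nitrile and a hydrogen-bond acceptor and the entering group has neither, yet the two numbers remain within the scatter of each other, although the group and its place on the ring change together and this one step cannot separate the two. Nothing measured here bears on why the two groups read alike.

Open, on these data alone, is whether a carboxylic acid or a primary amine on the same phenyl ring would carry the number beyond the scatter, and how 4-(trifluoromethyl)phenyl would read against both groups. Compound 2 and compound 3 each differ from compound 1 in more than one place, and the steps that would show what the chain bearing the amine contributes cannot be read.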